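This account rests on a few compounds, and the source may have more. Where it says the series, first, only, none or still open, it means among the compounds named here.

Compound 1 `CC(C)n1ncc2c(C(=O)Nc3ncccn3)cc(-c3ccsc3)nc21`: 50000 nM
Compound 2 `CC(C)n1ncc2c(C(=O)Nc3ncccn3)cc(-c3cccs3)nc21`: 75000 nM
Compound 3 `CC(C)n1ncc2c(C(=O)Nc3ccccc3F)cc(-c3ccccn3)nc21`: 100000 nM

Of the compounds shown here, three sharing one core have been measured in an ADME assay on LLC-MK2 cells (Macaca mulatta) for cytotoxicity, read by spectrophotometry and crystal violet staining, with a stated time of 4 days; a higher number here means that more compound is tolerated, a lower number that less compound is tolerated. Compound 2 stands second highest of the three numbers; its nearest neighbour is compound 3 and its furthest is compound 1, and both gaps lie within the scatter, so no order among the three can be read. Going by the values given here, the one single-point step recorded, a 1.5-fold higher number from compound 1 to compound 2 (0.18 log units; within the scatter), exchanges the group on the aromatic carbon and stays within the scatter.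

Compound 4 `CC(C)n1ncc2c(C(=O)Nc3cc(F)ccc3F)cc(-c3cccs3)nc21` differs from compound 2 in 2,5-difluorophenyl in place of pyrimidin-2-yl on an amide-type nitrogen. Among the compounds with values here, no measured step changes the group on the amide-type nitrogen alone. Compound 3 differs from compound 2 in several places at once, and compound 3 gives 100000 nM, a number close to that of compound 2. Within the data shown here, the only step recorded did not move the number beyond the scatter, and the three values sit within a narrow band, so the expected step of no change at the digits printed from compound 2 to compound 4 (within the scatter) is one that does not exceed the scatter, with no clear direction. Compound 4 is therefore estimated at 75000 nM, with a range from 40000 nM to 150000 nM.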

Compound 4, half-maximal cytotoxic concentration: 100000 nM
Estimate against measurement, compound 4: 1.3-fold (0.12 log units) below, and the stated range covers the measured number.
By their numbers in this assay, from the lowest: compounds 1, 2, 3 and 4 (each within the scatter of the next).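

In this assay, 2,5-difluorophenyl in place of pyrimidin-2-yl on the amide-type nitrogen gives a 1.3-fold higher number from compound 2 to compound 4 (0.12 log units; within the scatter) and is the only single-place step shown at this position. The exchange replaces a six-membered aromatic ring with 2 hetero atoms and 2 hydrogen-bond acceptors by a six-membered aromatic ring of carbon only, with 2 fluorines and 0 hydrogen-bond acceptors, and the step still stays within the scatter; at this position, then, these ring atoms and acceptors can differ with the thiophen-2-yl group held in place without the number moving beyond the scatter. No measurement is available that would explain this result.

The compounds shown cover only two aromatic rings on this nitrogen, so it remains open whether a saturated ring such as cyclohexyl, a longer alkyl chain, or a phenyl ring carrying an amine or a carboxylic acid would also stay within the scatter. As far as these compounds go, it is equally open whether the same exchange would read alike with thiophen-3-yl on the aromatic carbon, as in compound 1.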